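Adding a second methoxy group to compound 3

A few compounds are considered here, and "the series" means these few. Any claim that something is new, unique, unknown or untested is made for them only; others in the source may bear on it.

Measured values in a functional assay on SW480 cells (Homo sapiens) for antiproliferative activity, read by sulforhodamine B assay, with a stated time of 48 h (on this read-out higher numbers stand for weaker inhibition and lower numbers for stronger inhibition), are
- compound 1 `COc1ccc(/C=C/C(=O)c2ccccc2-c2ccc(OC)c(OC)c2)cc1OC` gives 7600 nM
- compound 2 `COc1ccc(/C=C/C(=O)c2ccccc2-c2ccc(F)cc2)cc1OC` gives 570 nM
- compound 3 `COc1ccc(/C=C/C(=O)c2ccccc2-c2cccc(F)c2)cc1` gives 140 nM

Of the three, compound 3 has the lowest number in this assay, with compound 2 nearest and compound 1 furthest. Compound 4 `COc1ccc(/C=C/C(=O)c2ccccc2-c2cccc(F)c2)cc1OC` differs from compound 3 by one change: methoxy in place of hydrogen on an aromatic carbon. This is methoxy in place of hydrogen on an aromatic carbon, ortho to a methoxy group and meta to a large group.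

Going by the values given here, no measured step makes this change. Among the compounds with values here, the only single-place step, a 13-fold lower number from compound 1 to compound 2 (1.12 log units; beyond the scatter), is large, but it is 4-fluorophenyl in place of 3,4-dimethoxyphenyl elsewhere in the molecule, so it bears only indirectly. The closer guide is a comparison of values: compound 4 shares its methoxy groups with compound 2, which differs only in the place of the fluorine and gives 570 nM. A modest move toward a higher number is therefore expected, near the edge of the scatter, as the estimated 2.1-fold higher number from compound 3 to compound 4 (0.33 log units; beyond the scatter). The estimate for compound 4 is 300 nM, with an expected range of 90 nM to 1000 nM.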

Compound 4, half-maximal inhibitory concentration: 160 nM
Estimate against measurement, compound 4: 1.9-fold (0.27 log units) above; low and high end bracket the measured number.
By their numbers in this assay, from the lowest: compounds 3 and 4 (each within the scatter of the next); then compound 2; then compound 1.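

In this assay, methoxy in place of hydrogen on this aromatic carbon, ortho to a methoxy group and meta to a large group, brings no readable change (a 1.1-fold higher number from compound 3 to compound 4 (0.06 log units; within the scatter)), so this position accepts the added group with the 3-fluorophenyl group in place. The steps beyond the scatter lie elsewhere in the molecule: 3-fluorophenyl in place of 4-fluorophenyl gives a 3.6-fold lower number from compound 2 to compound 4 (0.55 log units; beyond the scatter), and 3-fluorophenyl in place of 3,4-dimethoxyphenyl gives a 48-fold lower number from compound 1 to compound 4 (1.68 log units; beyond the scatter). No measurement at hand accounts for any of these steps.

On these data alone, whether this position would also accept an amine, a hydroxyl group or a longer chain such as ethoxy remains open. Also open, as far as these compounds go, is whether the methoxy change would read the same with 4-fluorophenyl or 3,4-dimethoxyphenyl in place of 3-fluorophenyl.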